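This account rests on a few compounds, and the source may have more. Where it says the series, first, only, none or still open, it means among the compounds named here.

Measured compounds:
- compound 1 `Cc1ccc(-c2ccnc(Nc3ccc4c(c3)c(/C=C3/C(=O)Nc5ccccc53)cn4C)n2)cc1`; in a functional assay on PA-1 cells (Homo sapiens) for cytotoxicity, read by MTT assay, with a stated time of 48 h (a higher number here means a weaker inhibitor, a lower number a stronger inhibitor), compound 1 gives > 100000 nM, which is a limit of the assay and not a number.
- compound 2 `COc1ccc(-c2ccnc(Nc3ccc4c(c3)c(/C=C3/C(=O)Nc5ccccc53)cn4C)n2)cc1`; in this assay compound 2 gives > 100000 nM, again a limit of the assay rather than a number.

Compound 2 therefore stands only at a limit in this assay, with no number of its own to place it against compound 1. Within the data shown here, the single measured step, a step that the two limits leave unreadable from compound 1 to compound 2, is unreadable, since both ends sit at the limit, as summarised by the limit of > 100000 nM in this assay, at which 2 of the 2 values shown sit.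

Compound 3 `Cn1cc(/C=C2/C(=O)Nc3ccccc32)c2cc(Nc3nccc(-c4cccnc4)n3)ccc21` differs from compound 2 in one place: pyridin-3-yl in place of 4-methoxyphenyl on an aromatic carbon. Among the measured compounds shown here, no measured step bears on this exchange; the only step changes a different substituent on the same aromatic carbon and gives no readable size. With both measured compounds at the limit, the expectation for compound 3 rests on that limit alone and on the small size of the change. The expected step is a step that the limit leaves unreadable from compound 2 to compound 3, nothing that could be read beyond the scatter. Compound 3 is therefore estimated at 150000 nM, within 30000 nM to 600000 nM, and is most likely again reported only as a limit.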

Compound 3, half-maximal inhibitory concentration: 18100 nM
The estimate for compound 3 lay 8.3-fold (0.92 log units) above the measured number; the measured number lies below the stated range.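

On an aromatic carbon of a six-membered aromatic ring with 2 nitrogen, the exchange of 4-methoxyphenyl for pyridin-3-yl gives the series its first readable number in this assay, with an at least 5.5-fold lower number from compound 2 to compound 3 (0.74 log units; beyond the scatter). The exchange of 4-methylphenyl for pyridin-3-yl at the same carbon gives the same reading, with an at least 5.5-fold lower number from compound 1 to compound 3 (0.74 log units; beyond the scatter), so the change in this set is tied to the aryl group at this carbon and does not depend on which of the two phenyl compounds serves as the reference. Both steps start from a limit of the assay and not a number, which makes their sizes lower bounds, and the two phenyl compounds remain unresolved from each other: the limit of > 100000 nM in this assay, at which 2 of the 3 values shown sit.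

The exchange removes the para-free description of neither effect alone, since the ring nitrogen enters while the methyl or methoxy group leaves, and a phenyl ring with no substituent at this carbon would be needed to separate the two. Also open, from the compounds shown here alone, is whether the placement of the ring nitrogen matters, which pyridin-4-yl or pyridin-2-yl at the same carbon would address.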